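Compound 3 and the stability of the series

The source may report more compounds than this note shows. Statements on the series, on what has been measured and on what is new or still open speak of the compounds shown alone.

Compounds measured in an ADME assay on microsomes from liver (Homo sapiens) for metabolic stability, with a stated time of 10 min; on this read-out lower numbers stand for a less stable compound and higher numbers for a more stable compound:
Compound 1 `C[C@]1(C(=O)O)CC[C@H](C(=O)N2CC[C@](c3ccc(C(F)(C(F)(F)F)C(F)(F)F)cc3)(S(=O)(=O)c3ccc(F)cc3)C2)CC1`: 97%
Compound 2 `O=C(O)[C@H]1CC[C@](F)(C(=O)N2CC[C@](c3ccc(C(F)(C(F)(F)F)C(F)(F)F)cc3)(S(=O)(=O)c3ccc(F)cc3)C2)CC1`: "not determined" (no result reported)

Compound 2 has no place on the numbers, since this assay gives no single result for it: for compound 2 the entry reads "not determined" (no result reported). The only figure for this series comes from compound 1, which stands at 97%.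

The next compound is compound 3 `NC(=O)[C@H]1CC[C@H](C(=O)N2CC[C@](c3ccc(C(F)(C(F)(F)F)C(F)(F)F)cc3)(S(=O)(=O)c3ccc(F)cc3)C2)CC1`, and the change leading to it is 4-carbamoylcyclohexyl in place of 4-carboxy-1-fluorocyclohexyl on a carbonyl carbon. The exchange sits on a carbonyl carbon whose other neighbour is an amide-type nitrogen in a ring, and the shared core stays untouched.

For the measured compounds named here, with no number for compound 2, no measured step can guide the expectation. A result close to compound 1 at 97% is expected, with no difference beyond the usual scatter, though a slight fall would not surprise.

For compound 3 the expected value is 90%, with an estimated range of 74% to 100%.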

Compound 3, percent of the compound remaining: 100%
The estimate for compound 3 lay 10 percentage points below the measured number, within the range that was stated.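

In this assay the series shows a number 3 percentage points higher from compound 1 to compound 3 (within the scatter) when 4-carbamoylcyclohexyl takes the place of 4-carboxy-4-methylcyclohexyl on a carbonyl carbon. For the compounds shown here, this gives the position a second measured group, and the two stand level within the scatter, which the single figure for compound 1 could not show. The step from compound 2 to compound 3 cannot be read, and nothing available speaks to why the two measured compounds sit together.

As far as these compounds go, both measured compounds lie near the top of the read-out, so it remains open whether any group on this carbonyl carbon would bring the number down. From the compounds shown here alone, an amine on the cyclohexyl ring, a plain cyclohexyl or a longer chain in its place could test that, and the effect of the fluorine of compound 2 also remains unknown.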